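Compound 3: trading 2,4-dimethylphenyl for 2,4,5-trichlorophenyl

The source may report more compounds than this note shows. Statements on the series, on what has been measured and on what is new or still open speak of the compounds shown alone.

In a functional assay on HT-29 cells (Homo sapiens) for antiproliferative activity, read by sulforhodamine B assay, with a stated time of 48 h (on this read-out lower numbers stand for stronger inhibition and higher numbers for weaker inhibition), compound 1 (`CCCN1CCN(c2ccc(S(=O)(=O)Oc3ccccc3CC)cc2)C1=O`) gives > 100000 nM as its reading, which is a limit of the assay and not a number. Among the measured compounds shown here, compound 2 (`CCCN1CCN(c2ccc(S(=O)(=O)Oc3ccc(C)cc3C)cc2)C1=O`) gives 26000 nM in this assay and so holds the only true number so far. For the measured compounds named here, the single measured step is an at least 3.8-fold lower number from compound 1 to compound 2 (0.58 log units; beyond the scatter) with 2,4-dimethylphenyl in place of 2-ethylphenyl on an oxygen. As far as these compounds go, that step rests on the limit of > 100000 nM in this assay, at which 1 of the 2 values shown sits, and its full size stays unknown. Compound 3 (`CCCN1CCN(c2ccc(S(=O)(=O)Oc3cc(Cl)c(Cl)cc3Cl)cc2)C1=O`) keeps the shared core and changes the same group, and 2,4,5-trichlorophenyl in place of 2,4-dimethylphenyl on an oxygen is the whole difference. Going by the values given here, the one step of an at least 3.8-fold lower number from compound 1 to compound 2 (0.58 log units; beyond the scatter) involves a different exchange and gives no direction for this new one. The expected change is a 1.3-fold lower number from compound 2 to compound 3 (0.11 log units; within the scatter) and thus nothing beyond the scatter. Compound 3 is estimated at 20000 nM in this assay with an expected range from 6000 nM to 80000 nM here.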

Compound 3, half-maximal inhibitory concentration: 19000 nM
Estimate against measurement, compound 3: 1.1-fold (0.02 log units) above; the measured number falls inside the stated range.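

In this assay there is a 1.4-fold lower number from compound 2 to compound 3 (0.14 log units; within the scatter) and so no real difference: on an oxygen whose other neighbours are a sulfonyl sulfur, 2,4,5-trichlorophenyl and 2,4-dimethylphenyl cannot be told apart, although chlorine enters where the group before held only carbon. Against 2-ethylphenyl, the trichlorophenyl group acts as the dimethylphenyl group did, with an at least 5.2-fold lower number from compound 1 to compound 3 (0.72 log units; beyond the scatter) as the second step that leaves 2-ethylphenyl for a lower number. As far as these compounds go, compound 1 reads > 100000 nM in this assay, which is a limit and not a number, so the full size of that step stays unknown: the limit of > 100000 nM in this assay, at which 1 of the 3 values shown sits.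

From the compounds shown here alone, whether a phenyl ring carrying an amine or a carboxylic acid would behave the same way stays open. So does the effect of a longer chain in place of the propyl group on the shared core.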